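Pairing Two Potency-Lowering Changes on a Shared Core

The compounds below may be only part of what the source reports. "The series", "measured", "known", "first", "only" and "open" are said of these compounds alone.

Compound 1 `Cc1ccc(Nc2nc(SCc3cn(CC(=O)NC(=O)Nc4ccccn4)nn3)nc(-c3ccc(C)cc3)c2C#N)cc1` gives 1010 nM in a functional assay on B16-F10 cells (Mus musculus) for inhibition, read by MTT assay, with a stated time of 72 h; on this read-out lower numbers stand for stronger inhibition and higher numbers for weaker inhibition. Compound 2 `Cc1ccc(-c2nc(SCc3cn(CC(=O)NC(=O)Nc4ccccn4)nn3)nc(Nc3cccc(C(F)(F)F)c3)c2C#N)cc1` gives 9580 nM in this assay, and compound 3 `Cc1ccc(Nc2nc(SCc3cn(CC(=O)NC(=O)Nc4ccccn4)nn3)nc(-c3ccc(Br)cc3)c2C#N)cc1` gives 8160 nM. The first pair shows a 9.5-fold higher number from compound 1 to compound 2 (0.98 log units; beyond the scatter), tied to the change (3-(trifluoromethyl)phenyl in place of 4-methylphenyl on a nitrogen on an aromatic ring). The second pair shows an 8.1-fold higher number from compound 1 to compound 3 (0.91 log units; beyond the scatter), tied to bromo in place of methyl on an aromatic carbon, which is how the core of compound 3 differs from the core of compound 1. Compound 4 `N#Cc1c(Nc2cccc(C(F)(F)F)c2)nc(SCc2cn(CC(=O)NC(=O)Nc3ccccn3)nn2)nc1-c1ccc(Br)cc1` has not been measured; it differs from compound 3 by 3-(trifluoromethyl)phenyl in place of 4-methylphenyl on a nitrogen on an aromatic ring, the same change seen between the first pair, at a place described in identical words. Among the compounds with values here, because a 9.5-fold higher number from compound 1 to compound 2 (0.98 log units; beyond the scatter) was found for this change, compound 4 is expected to take a step of similar size, a 6.1-fold higher number from compound 3 to compound 4 (0.79 log units; beyond the scatter), with no second example to confirm it. Compound 4 is therefore estimated at 50000 nM, between 15000 nM and 150000 nM.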

Compound 4, half-maximal inhibitory concentration: 4550 nM
Beside the measured number, compound 4's estimate is 11-fold (1.04 log units) above it, outside the stated range (below it).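

In this assay, the step to 3-(trifluoromethyl)phenyl on the bromo-bearing core is a 1.8-fold lower number from compound 3 to compound 4 (0.25 log units; within the scatter), which lies within the scatter, so the large rise in number seen on the core of compound 1 does not carry over: the same change on two cores in this assay, a 9.5-fold higher number (0.98 log units; beyond the scatter) from compound 1 to compound 2 and a 1.8-fold lower number (0.25 log units; within the scatter) from compound 3 to compound 4, 17-fold (1.23 log units) apart, beyond the scatter of two such steps. Bromo in place of methyl also behaves differently on the two cores, with a 2.1-fold lower number from compound 2 to compound 4 (0.32 log units; beyond the scatter) where the nitrogen carries 3-(trifluoromethyl)phenyl: the same change on two cores in this assay, an 8.1-fold higher number (0.91 log units; beyond the scatter) from compound 1 to compound 3 and a 2.1-fold lower number (0.32 log units; beyond the scatter) from compound 2 to compound 4, 17-fold (1.23 log units) apart, beyond the scatter of two such steps. Thus the two changes do not simply add up in these four compounds, but this single set does not show how either change would behave on any further core, or why the steps differ.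

The compounds shown leave open whether a chloro on that aromatic carbon, or a longer alkyl chain on that nitrogen, would follow the pattern of compound 1 or that of compound 3.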